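This account rests on a few compounds, and the source may have more. Where it says the series, first, only, none or still open, it means among the compounds named here.

Compound 1, `Cc1cn(C2CCN(Cc3cccc(Oc4cccnc4)c3)CC2)c(=O)[nH]c1=O`, gives > 64000 nM in an ADME assay on MRC5 cells (Homo sapiens) for cytotoxicity, read by fluorescence and resazurin assay, with a stated time of 3 days; a higher number here means a weaker inhibitor, a lower number a stronger inhibitor.
Compound 2, `Cc1cn(C2CCN(Cc3cccc(Oc4cccc(Cl)c4)n3)CC2)c(=O)[nH]c1=O`, gives > 64000 nM in this assay.
Compound 3, `Cc1cn(C2CCN(Cc3cncc(Oc4cccc(OC(F)(F)F)c4)c3)CC2)c(=O)[nH]c1=O`, gives > 64000 nM in this assay.

Each of these three values is a limit of the assay rather than a number: the measurement went no further, so all that is known is that none of the three compounds harmed the cells within the tested range. Compound 1 therefore stands at the limit of > 64000 nM in this assay, at which 3 of the 3 values shown sit, and on the numbers shown nothing separates it from the other two.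

Compound 4, `Cc1cn(C2CCN(Cc3cccc(OC4CCCCC4)c3)CC2)c(=O)[nH]c1=O`, is the next compound to be tested in this assay. It differs from compound 1 in a single place: cyclohexyl in place of pyridin-3-yl on an oxygen on an aromatic ring. The aromatic ring that carried the oxygen, and the whole remainder of the shared core, stay as they are.

For the measured compounds named here, no pair of measured compounds that differ in one place is available here, so the size of this step has to be anticipated without a direct precedent. Given that compound 1 and its two companions all sit at the limit, the expectation is a step that the limit leaves unreadable from compound 1 to compound 4, that is, no change beyond the usual scatter. Compound 4 is accordingly estimated at 80000 nM, between 30000 nM and 200000 nM, with a good chance that the assay again reports only a limit.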

Compound 4, half-maximal inhibitory concentration: 23600 nM
Beside the measured number, compound 4's estimate is 3.4-fold (0.53 log units) above it; the whole stated range lies above it.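

In this assay, replacing pyridin-3-yl with cyclohexyl on the oxygen gives an at least 2.7-fold lower number from compound 1 to compound 4 (0.43 log units; beyond the scatter), so what sits at this place does affect how the cells respond, and a lower number here means more harm to them. The step is a minimum, as compound 1 has no exact value to measure from, but compound 4 at 23600 nM is the first compound shown to reach a measurable effect on the cells within the tested range. The other compounds give no such number, so this is the only step that can be read: the limit of > 64000 nM in this assay, at which 3 of the 4 values shown sit.

This one change swaps an aromatic ring for a non-aromatic one and also removes the ring nitrogen, so the compounds shown leave open which of the two differences matters. A plain phenyl on the same oxygen would pull these two differences apart, while cyclopentyl or an open hexyl chain would test whether the effect depends on the cyclohexyl ring itself.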